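A few compounds are considered here, and "the series" means these few. Any claim that something is new, unique, unknown or untested is made for them only; others in the source may bear on it.

Working notes on the series. The shared core appears in compound 1 `COc1cc(N2C(N)=C(C#N)C(c3ccccc3O)C3=C2CC(C)(C)CC3=O)cc(OC)c1OC` and compound 2 `COc1cc(N2C(N)=C(C#N)C(c3c(O)ccc4ccccc34)C3=C2CC(C)(C)CC3=O)cc(OC)c1OC`. In a functional assay on Ehrlich cells (Mus musculus) for cytotoxicity (on this read-out lower numbers stand for stronger inhibition and higher numbers for weaker inhibition), compound 1 is recorded as "not active" (no number reported), with no number attached. In this assay, among the compounds with values here, compound 2 gives 143000 nM, the only numbered result, so compound 2 stands alone and no ordering among measured compounds can be drawn. Compound 3 `COc1cc(N2C(N)=C(C#N)C(c3ccc(C)cc3)C3=C2CC(C)(C)CC3=O)cc(OC)c1OC` is not yet measured; it differs from compound 2 by 4-methylphenyl in place of 2-hydroxynaphthalen-1-yl on a saturated ring carbon. No measured pair in the series carries this change, so nothing shown gives its size directly. Compound 1, which likewise lacks the 2-hydroxynaphthalen-1-yl group, returned no number; the expectation is that the step of a 1.7-fold higher number from compound 2 to compound 3 (0.24 log units; within the scatter) runs toward weaker inhibition or stays within the scatter. For compound 3 the estimate in this assay is 250000 nM, with a range from 100000 nM to 800000 nM, and a real chance that only a limit is reported.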

Compound 3, half-maximal inhibitory concentration: 52900 nM
Beside the measured number, compound 3's estimate is 4.7-fold (0.67 log units) above it; measured number below the stated range.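

In this assay, the saturated ring carbon carrying the aryl group tolerates a change of group, with a 2.7-fold lower number from compound 2 to compound 3 (0.43 log units; beyond the scatter) on replacing 2-hydroxynaphthalen-1-yl with 4-methylphenyl; the second aromatic ring and the hydrogen-bond donor and acceptor of the leaving group are therefore not needed for a numbered result. A single aromatic ring at this carbon does not settle the outcome on its own, since compound 3 has a number while compound 1 gives "not active" (no number reported). Nothing measured here accounts for the step.

The change alters the ring count, the hydroxyl and the methyl all at once, so their separate contributions remain unresolved. As far as these compounds go, a 4-hydroxyphenyl, 4-methoxyphenyl or 4-aminophenyl group, or a naphthalen-1-yl group without the hydroxyl, remains open at this carbon.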